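Alkyl urea series: isopropyl gives way to heptyl

The compounds below may be only part of what the source reports. "The series", "measured", "known", "first", "only" and "open" are said of these compounds alone.

Compound 1 `CC(C)c1ccccc1NC(=O)N[C@@H](C)c1ccccc1`, compound 2 `CC(C)c1ccc(NC(=O)N[C@H](C)c2ccccc2)cc1` and compound 3 `CC(C)c1ccc(NC(=O)N[C@@H](C)c2ccccc2)cc1` share one urea core. In an ADME assay on the whole organism with Oryza sativa as the target, tested at 1 uM (on this read-out higher numbers stand for a weaker effect at the one concentration tested and lower numbers for a stronger effect), compound 1 gives 96%, compound 2 gives 79% and compound 3 gives 96%. Compound 3 thus stands level with compound 1, the two together the highest of the three, and furthest from compound 2. For the measured compounds named here, the only measured step, a number 17 percentage points higher from compound 2 to compound 3 (beyond the scatter), rests on (the fact that compounds 2 and 3 differ only in the configuration as drawn). Compound 4 `CCCCCCCc1ccc(NC(=O)N[C@@H](C)c2ccccc2)cc1` differs from compound 3 by heptyl in place of isopropyl on an aromatic carbon. Going by the values given here, no measured step alters the alkyl group, so the configuration step offers no guide to the size of this change. Compound 4 is therefore expected to stay close to compound 3, with a number 4 percentage points lower from compound 3 to compound 4 (within the scatter) expected to remain within the scatter. Compound 4 is estimated at 92%, within 75% to 100%.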

Compound 4, a percentage reported as activity, at one concentration (the size of the read-out at that concentration, not a potency): 99%
The estimate for compound 4 lay 7 percentage points below the measured number, within the range that was stated.
By their numbers in this assay, from the lowest: compound 2; then compounds 1, 3 and 4 (each within the scatter of the next).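

In this assay, the place on an aromatic carbon para to a large group now has a step of its own, with heptyl in place of isopropyl: a number 3 percentage points higher from compound 3 to compound 4 (within the scatter). With the configuration of compound 3 held, the read-out therefore does not separate these two alkyl groups. No available evidence bears on this alkyl change.

As far as these compounds go, it remains open whether an amine or a carboxylic acid at this place would shift the read-out. From the compounds shown here alone, it also remains open whether heptyl would behave the same with the configuration of compound 2.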